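Replacing the acetylpiperidine amide with a hydroxamate

The compounds below may be only part of what the source reports. "The series", "measured", "known", "first", "only" and "open" are said of these compounds alone.

Measured compounds:
- compound 1 `CC(=O)N1CCC(C(=O)N2CC[C@H](C(=O)N(C)Cc3cc(C(F)(F)F)cc(C(F)(F)F)c3)[C@@H](c3ccc(C)cc3)C2)CC1` gives 0.18 nM
- compound 2 `CCc1ccccc1[C@H]1CN(C(=O)C2CCN(C(C)=O)CC2)CC[C@@H]1C(=O)N(C)Cc1cc(C(F)(F)F)cc(C(F)(F)F)c1` gives 0.064 nM
- compound 3 `CC(=O)N1CCC(C(=O)N2CC[C@H](C(=O)N(C)Cc3cc(C(F)(F)F)cc(C(F)(F)F)c3)[C@@H](c3ccc(F)cc3C)C2)CC1` gives 0.047 nM

All three were tested in an assay on IM-9 cells for displacement of a labelled ligand from Substance-P receptor (Homo sapiens), read by scintillation counting, with a stated time of 30 min; on this read-out lower numbers stand for stronger inhibition and higher numbers for weaker inhibition. Compound 3 holds the lowest number of the three: compound 1 is the furthest from it, with a 3.8-fold lower number from compound 1 to compound 3 (0.58 log units; beyond the scatter), while compound 2 sits close, with a 1.4-fold lower number from compound 2 to compound 3 (0.13 log units; within the scatter). The two lie within the scatter of each other, so no order between compound 2 and compound 3 can be claimed.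

Compound 4 `Cc1cc(F)ccc1[C@H]1CN(C(=O)C(=O)NO)CC[C@@H]1C(=O)N(C)Cc1cc(C(F)(F)F)cc(C(F)(F)F)c1` has not been measured in this assay. It differs from compound 3 at a different place than any measured step: hydroxycarbamoyl in place of 1-acetylpiperidin-4-yl on a carbonyl carbon. The steps that are known, including a 2.8-fold lower number from compound 1 to compound 2 (0.45 log units; beyond the scatter), all change the aryl group on the saturated ring carbon, and none of them touches the acyl group on the ring nitrogen. Going by the values given here, there is therefore no measured step that bears on this change, and the expected direction cannot be read from the data. The estimate is kept wide, with a modest loss taken as the middle: compound 4 is expected to give about 0.3 nM, between 0.05 nM and 3 nM, which means an expected step of a 6.4-fold higher number from compound 3 to compound 4 (0.81 log units; beyond the scatter).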

Compound 4, half-maximal inhibitory concentration: 0.046 nM
Estimate against measurement, compound 4: 6.5-fold (0.81 log units) above; measured number outside the range, below it.
By their numbers in this assay, from the lowest: compounds 4, 3 and 2 (each within the scatter of the next); then compound 1.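

Going by these compounds alone, until this point, every step changed the aryl group on the saturated ring carbon, so this is the first view of what the group on the carbonyl carbon can tolerate. In this assay, there is a 1.0-fold lower number from compound 3 to compound 4 (0.01 log units; within the scatter), so 1-acetylpiperidin-4-yl, with its six-membered ring and 9 heavy atoms, can be exchanged for hydroxycarbamoyl, with no ring and 4 heavy atoms, without a difference that this read-out can resolve. Nothing shown here explains why two such different groups read alike.

Hydroxycarbamoyl appears with only the 4-fluoro-2-methylphenyl group, so it remains open whether the result would hold with the 2-ethylphenyl group of compound 2 or the 4-methylphenyl group of compound 1. On these data alone, it is also open how a carboxylic acid, a primary amine or a longer chain ending in hydroxycarbamoyl would read at this carbonyl carbon.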